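The compounds below may be only part of what the source reports. "The series", "measured", "known", "first", "only" and "open" are said of these compounds alone.

Working notes on the sulfone series. Compound 1 `CN(C)CCn1cc(S(=O)(=O)c2cc(Cl)cc(Cl)c2)c2cccnc21` in an assay on HeLa cells for displacement of a labelled ligand from 5-hydroxytryptamine receptor 6 (Homo sapiens) (a lower number here means a stronger inhibitor, a higher number a weaker inhibitor), gives 4.3 nM. Compound 2 `NCCn1cc(S(=O)(=O)c2cc(Cl)cc(Cl)c2)c2cccnc21` in this assay gives 2.9 nM, and a 1.5-fold lower number from compound 1 to compound 2 (0.17 log units; within the scatter), so the two measured compounds sit together and compound 1 is not set apart from compound 2. Compound 3 `CN(C)CCn1cc(S(=O)(=O)c2cccs2)c2cccnc21` differs from compound 1 by thiophen-2-yl in place of 3,5-dichlorophenyl on a sulfonyl sulfur. Among the compounds with values here, no measured step touches the sulfonyl substituent; the one step on record alters only the amine, so it gives no direct guide to this change. A modest shift toward a weaker number is expected, a 3.5-fold higher number from compound 1 to compound 3 (0.54 log units; beyond the scatter), so compound 3 is estimated at 15 nM, within 3 nM to 70 nM.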

Compound 3, inhibition constant: 15 nM
Compound 3: middle estimate and measured number agree at the digits printed; the range from low to high includes it.
By their numbers in this assay, from the lowest: compounds 2 and 1 (each within the scatter of the next); then compound 3.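

Within the data shown here, the sulfonyl substituent is the first position where a measured step goes beyond the scatter: in this assay, thiophen-2-yl in place of 3,5-dichlorophenyl on a sulfonyl sulfur gives a 3.5-fold higher number from compound 1 to compound 3 (0.54 log units; beyond the scatter) and so matters more than the amine step did. The 3,5-dichlorophenyl group is not required for binding, since compound 3 still gives 15 nM with the smaller thiophen-2-yl. Nothing on hand accounts for the shift.

Open, as far as these compounds go, is whether the same step holds with the amino chain of compound 2, and whether an unsubstituted phenyl or a pyridinyl on the sulfonyl sulfur lies nearer compound 1 or compound 3.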